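Pyrrolidinyl in place of chloroanilino on two cores

The source may report more compounds than this note shows. Statements on the series, on what has been measured and on what is new or still open speak of the compounds shown alone.

Measured so far in a functional assay on MGC-803 cells (Homo sapiens) for inhibition, read by sulforhodamine B assay; a lower number here means a stronger inhibitor, a higher number a weaker inhibitor:
- compound 1 `O=C1C(N2CCCC2)=CC(=O)c2c1nc1n2[C@H]2OC[C@@H](O)[C@H]2OC1`: the value for compound 1 is a limit of the assay, > 16000 nM.
- compound 2 `O=C1C=C(Nc2cccc(Cl)c2)C(=O)c2c1nc1n2[C@H]2OC[C@@H](O)[C@H]2OC1`: compound 2 gives 1770 nM.
- compound 3 `O=C1C(Nc2cccc(Cl)c2)=CC(=O)c2c1nc1n2[C@H]2OC[C@@H](O)[C@H]2OC1`: compound 3 gives 1530 nM.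

Compounds 2 and 3 are built from the same atoms joined differently; the difference between the two cores is not broken down here. Their two values lie within the scatter of each other.

On the core of compound 3, exchanging pyrrolidin-1-yl in place of (3-chlorophenyl)amino on a double-bonded ring carbon gives compound 1, and this step is an at least 10-fold higher number from compound 3 to compound 1 (1.01 log units; beyond the scatter); the value of compound 1 sits at the limit of > 16000 nM in this assay, at which 1 of the 3 values shown sits.

Compound 4 `O=C1C=C(N2CCCC2)C(=O)c2c1nc1n2[C@H]2OC[C@@H](O)[C@H]2OC1` is not yet measured. It arises from compound 2 by the exchange (pyrrolidin-1-yl in place of (3-chlorophenyl)amino on a double-bonded ring carbon), the same change on the same kind of place as from compound 3 to compound 1.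

For compound 4 in this assay a step of a 10-fold higher number from compound 2 to compound 4 (1.01 log units; beyond the scatter) is expected, because an at least 10-fold higher number from compound 3 to compound 1 (1.01 log units; beyond the scatter) was the size of the step when the same change was made on the other core. Compound 4 is therefore estimated at 18000 nM, between 8000 nM and 50000 nM, with a fair chance that only a limit is reported.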

Compound 4, half-maximal inhibitory concentration: > 16000 nM
Compound 4: no number, only a limit (the forecaster's own chance of this, stated with the estimate: 65%); the middle value is on the limit's open side.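

In this assay compound 4 gives > 16000 nM, which is a limit of the assay and not a number. Pyrrolidin-1-yl in place of (3-chlorophenyl)amino again gives a weaker inhibitor on this second core, with an at least 9.0-fold higher number from compound 2 to compound 4 (0.95 log units; beyond the scatter), so the direction of the change carries from one core to the other: the same change on two cores in this assay, an at least 10-fold higher number (1.01 log units; beyond the scatter) from compound 3 to compound 1 and an at least 9.0-fold higher number (0.95 log units; beyond the scatter) from compound 2 to compound 4; the limit leaves it open whether they differ. This holds for these two pairs only, and the true size of each step remains unread, so the data do not show whether the change costs the same on both cores.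

Going by these compounds, it remains open whether the loss follows the aromatic ring, the chlorine or the amine hydrogen of the (3-chlorophenyl)amino group. The position in this assay of phenylamino without the chlorine, or of an open-chain amine such as dimethylamino, would help separate these features and could bring values on both cores back within the readable range.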